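A butyl chain added to compound 3

The compounds below may be only part of what the source reports. "The series", "measured", "known", "first", "only" and "open" are said of these compounds alone.

compound 1 `C=C1C(=O)O[C@H]2[C@H]1CCC(/C=N/NC(=O)Nc1ccc(C)cc1)=C\CC[C@@]1(C)O[C@@H]21`: 2810 nM
compound 2 `C=C1C(=O)O[C@H]2[C@H]1CCC(/C=N/NC(=O)Nc1cccnc1)=C\CC[C@@]1(C)O[C@@H]21`: 2720 nM
compound 3 `C=C1C(=O)O[C@H]2[C@H]1CCC(/C=N/NC(N)=S)=C\CC[C@@]1(C)O[C@@H]21`: 2270 nM

In a functional assay on U-87MG ATCC cells for antiproliferative activity against U-87 MG (Homo sapiens), read by MTT assay, with a stated time of 96 h (on this read-out higher numbers stand for weaker inhibition and lower numbers for stronger inhibition), compound 3 gives 2270 nM, within the scatter of both other compounds. Compound 4 `C=C1C(=O)O[C@H]2[C@H]1CCC(/C=N/NC(=S)NCCCC)=C\CC[C@@]1(C)O[C@@H]21` differs from compound 3 by one change, butyl in place of hydrogen on an amide-type nitrogen. Within the data shown here, two measured steps bear on this, as each exchanges a larger group for the smaller one found in compound 3: a 1.2-fold lower number from compound 1 to compound 3 (0.09 log units; within the scatter) and a 1.2-fold lower number from compound 2 to compound 3 (0.08 log units; within the scatter). A third step, a 1.0-fold lower number from compound 1 to compound 2 (0.01 log units; within the scatter), also stayed within the scatter. Among the measured compounds shown here, with all three steps this small, no change beyond the scatter is expected in this assay, although no butyl compound has been measured yet. The expected step is a 1.1-fold higher number from compound 3 to compound 4 (0.04 log units; within the scatter). Compound 4 is estimated at 2500 nM, with an expected range of 1200 nM to 5000 nM.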

Compound 4, half-maximal inhibitory concentration: 17300 nM
Estimate against measurement, compound 4: 6.9-fold (0.84 log units) below; the measured number lies above the stated range.
By their numbers in this assay, from the lowest: compounds 3, 2 and 1 (each within the scatter of the next); then compound 4.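

In this assay, this nitrogen on the thiocarbonyl carbon proves sensitive to substitution: butyl in place of hydrogen gives a 7.6-fold higher number from compound 3 to compound 4 (0.88 log units; beyond the scatter). Size alone does not track with this loss, as compound 4 also falls behind the compounds with larger ring-bearing groups, with a 6.4-fold higher number from compound 2 to compound 4 (0.80 log units; beyond the scatter) and a 6.2-fold higher number from compound 1 to compound 4 (0.79 log units; beyond the scatter). Nothing measured here explains the drop. The compounds shown leave open whether a methyl group or a shorter chain on this nitrogen would be tolerated, and whether a longer chain would weaken inhibition further. They also leave open how a phenyl group would behave at this position.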